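The source may hold more compounds than are shown below. What is called first, only, known or untested is meant among the compounds shown, and "the series" means these compounds.

Series notes. Three compounds sharing one core have been run in a functional assay (B cells) with Mus musculus as the target; a lower number here means that less compound is needed, a higher number that more compound is needed for the effect. Compound 1 `Nc1nc(O)c2c(n1)n(C1OC(CO)[C@@H](O)[C@H]1O)c(=O)n2Cc1ccc(Cl)cc1` gives 14 uM in this assay. Compound 2 `C=CCn1c(=S)n(COCCO)c2nc(N)nc(O)c21` gives 14 uM in this assay, level with compound 1 at the digits shown; together they hold the two lowest numbers of the three, though every gap in the set lies within the scatter. Compound 3 `CCCn1c(=O)n(C2OC(COP(=O)(O)O)[C@@H](O)[C@H]2O)c2nc(N)nc(O)c21` gives 15 uM in this assay, a number that sits within the scatter of compound 1, so no order can be read between them. Going by the values given here, the three differ from one another in several places at once, and no single-change step between measured compounds is available.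

Compound 4 `N#Cc1ccc(Cn2c(=O)n(C3OC(CO)[C@@H](O)[C@H]3O)c3nc(N)nc(O)c32)cc1` has not yet been measured in this assay. It is related to compound 1 by one change: cyano in place of chloro on an aromatic carbon. In the wider reading, 4-chlorobenzyl becomes 4-cyanobenzyl, with the rest of compound 1 kept. Nothing in the measured set shows what this change does here. Because compound 1 stands at 14 uM and the whole set sits within the scatter of it, the step expected for compound 4, a 1.2-fold lower number from compound 1 to compound 4 (0.07 log units; within the scatter), is small, with no direction claimed beyond the scatter. Compound 4 is therefore estimated at 12 uM in this assay, within a range from 5 uM to 30 uM.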

Compound 4, concentration for half-maximal effect: 15 uM
Compound 4: middle estimate off by 1.3-fold (0.10 log units), on the low side, within the range that was stated.
By their numbers in this assay, from the lowest: compounds 1, 2, 3 and 4 (each within the scatter of the next).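

In this assay, going by these compounds alone, cyano in place of chloro on an aromatic carbon, para to a large group, gives a 1.1-fold higher number from compound 1 to compound 4 (0.03 log units; within the scatter), the first single-change step and one that lies within the scatter. Unlike the earlier comparisons, which mixed several differences at once, this one isolates a single place: 4-chlorobenzyl and 4-cyanobenzyl cannot be ordered here, even though the cyano group has one more heavy atom than chloro and carries a hydrogen-bond acceptor. The measurements offer no explanation for the absence of a readable step at this position.

Going by these compounds, one exchange at one position does not define how much this position tolerates, so it remains open whether an amine, a carboxylic acid or a methoxy group on the same aromatic carbon would give a step beyond the scatter. On these data alone, it also remains open whether a longer chain in place of the benzyl methylene would do so, and compound 2 and compound 3 cannot address either question, as they differ from compound 1 in several places.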